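The source may hold more compounds than are shown below. What is called first, only, known or untested is meant among the compounds shown, and "the series" means these compounds.

For the measured compounds named here, compound 2 `Cc1ccc(C(=O)O)cc1OCCCCOc1ccc(C(=O)CC(C)C)c(O)c1C` gives the only numerical reading here: in an assay on HEK293 cells for positive allosteric modulation of metabotropic glutamate receptor 2 (Rattus norvegicus), read by thallium flux, with a stated time of 2.5 min (on this read-out higher numbers stand for an effect only at larger amounts of compound and lower numbers for an effect already at smaller amounts), compound 2 gives 454 nM. Compound 1 `Cc1c(OCCCCOc2ccc(C(=O)O)c(Cl)c2)ccc(C(=O)CC(C)C)c1C` sits at a limit of this assay, reporting > 10000 nM, so its reading is a boundary rather than a number, as the limit of > 10000 nM in this assay, at which 1 of the 2 values shown sits, records. Compound 3 `Cc1c(OCCCCOc2ccc(C(=O)O)c(Cl)c2)ccc(C(=O)CC(C)C)c1O` has not yet been measured in this assay. It differs from compound 2 by 4-carboxy-3-chlorophenyl in place of 5-carboxy-2-methylphenyl on an oxygen on a saturated carbon. Going by the values given here, no measured step covers this change, so the expected step from compound 2 to compound 3 is uncertain; a weakening is estimated, a 4.4-fold higher number from compound 2 to compound 3 (0.64 log units; beyond the scatter). Compound 3 is therefore expected to give about 2000 nM, within 500 nM to 10000 nM.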

Compound 3, half-maximal effective concentration: 151 nM
Compound 3: the middle estimate sits 13-fold (1.12 log units) above what was measured; the measured number lies below the stated range.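

On this assay, 4-carboxy-3-chlorophenyl in place of 5-carboxy-2-methylphenyl on the oxygen gives a 3.0-fold lower number from compound 2 to compound 3 (0.48 log units; beyond the scatter), so the new aryl group on this chain improves the reading rather than weakening it. With that group held constant, hydroxy in place of methyl on an aromatic carbon gives an at least 66-fold lower number from compound 1 to compound 3 (1.82 log units; beyond the scatter), which makes this the larger of the two changes. The reading of compound 1 is a limit and not a number: the limit of > 10000 nM in this assay, at which 1 of the 3 values shown sits.

The compounds shown leave open how an amine or a methoxy group would read in place of that hydroxy. They also leave open whether a bromine in place of the chlorine would keep the step.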